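The source may hold more compounds than are shown below. What is called first, only, known or untested is meant among the compounds shown, and "the series" means these compounds.

Measured in a physicochemical assay for metabolic stability, read by HPLC; a lower number here means that the compound disappears faster, a higher number that the compound lasts longer:
- Compound 1 `O=c1ccn([C@H]2CC[C@@H](COP(=O)(O)Oc3ccncc3)O2)c(=O)[nH]1`: 23.6 h
- Compound 2 `Cc1cn([C@H]2C[C@H](N=[N+]=[N-])[C@@H](COP(=O)(O)Oc3ccc(C#N)cc3)O2)c(=O)[nH]c1=O`: 7.08 h

Of these two, compound 2 has the lower number, and its gap to compound 1 lies beyond the usual scatter. Compound 3 `Cc1ncccc1OP(=O)(O)OC[C@H]1O[C@@H](n2cc(C)c(=O)[nH]c2=O)C[C@@H]1N=[N+]=[N-]` is still unmeasured. It departs from compound 2 in one place, with 2-methylpyridin-3-yl in place of 4-cyanophenyl on an oxygen. Among the measured compounds shown here, no measured pair differs in one place only, so there is no direct precedent for this change. For the measured compounds named here, the sole other reference is compound 1 at 23.6 h, which gives only weak support for expecting movement towards the higher number. A modest rise in this assay is therefore expected, though it may not clear the scatter, with the estimated step being a 1.7-fold higher number from compound 2 to compound 3 (0.23 log units; within the scatter). The half-life expected for compound 3 is 12 h, with an estimated range from 5.5 h to 28 h.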

Compound 3, half-life: 15.8 h
Estimate against measurement, compound 3: 1.3-fold (0.12 log units) below; the measured number falls inside the stated range.
By their numbers in this assay, from the lowest: compound 2; then compounds 3 and 1 (each within the scatter of the next).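

Among the compounds shown here, on an oxygen whose other neighbour is phosphorus, 2-methylpyridin-3-yl in place of 4-cyanophenyl gives the first comparison in this assay in which only one place differs, and it reads as a 2.2-fold higher number from compound 2 to compound 3 (0.35 log units; beyond the scatter). With the rest of the structure unchanged, the group on this oxygen alone is thus enough to shift the half-life beyond the usual scatter, though the step is modest. Nothing available gives a cause for this step.

The compounds shown leave open whether the ring nitrogen, the methyl group or the loss of the nitrile goes with the step, a question that plain phenyl, pyridin-3-yl or 2-methylphenyl on this oxygen could help to separate. As far as these compounds go, it also remains open how a non-aromatic group, such as an ethyl chain, would read in this assay at this place.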